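Changing the Aryl Group on the Saturated Ring Carbon

The source may report more compounds than this note shows. Statements on the series, on what has been measured and on what is new or still open speak of the compounds shown alone.

Compound 1 `N#CC1=C(N)N(c2ccc(S(N)(=O)=O)cc2)C2=C(CCCC2)C1/C=C/c1ccccc1` and compound 2 `COc1ccc(C2C(C#N)=C(N)N(c3ccc(S(N)(=O)=O)cc3)C3=C2CCCC3)cc1` share one core and differ only in the group on a saturated ring carbon. In a functional assay on Ehrlich cells (Mus musculus) for cytotoxicity, read by trypan blue exclusion, with a stated time of 2 h, tested at 10 ug/mL (a lower number here means a weaker effect, a higher number a stronger effect of the compound at the concentration tested), compound 1 gives 50%, and compound 2 gives 50%. Going by the values given here, the step of no change at the digits printed from compound 1 to compound 2 (within the scatter) thus lies within the scatter, and compound 2 stands level with compound 1, its only measured neighbour.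

Compound 3 `N#CC1=C(N)N(c2ccc(S(N)(=O)=O)cc2)C2=C(CCCC2)C1c1cccc([N+](=O)[O-])c1` arises from compound 2 through a single change: 3-nitrophenyl in place of 4-methoxyphenyl on a saturated ring carbon. Among the compounds with values here, the one measured step that bears on this change is the earlier exchange at the same saturated ring carbon, no change at the digits printed from compound 1 to compound 2 (within the scatter), which was flat. Within the data shown here, with a single flat step as the only guide, the expected step is no change at the digits printed from compound 2 to compound 3 (within the scatter), that is, none beyond the scatter. Compound 3 is therefore estimated to give 50%, with a range from 30% to 70%, though one prior step is a thin basis.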

Compound 3, a percentage reported as activity, at one concentration (the size of the read-out at that concentration, not a potency): 0%
Estimate against measurement, compound 3: 50 percentage points above, and the stated range ends above it.
By their numbers in this assay, from the lowest: compound 3; then compounds 1 and 2 (each within the scatter of the next).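

In this assay, putting 3-nitrophenyl on the saturated ring carbon gives a number 50 percentage points lower from compound 2 to compound 3 (beyond the scatter), and the same position gives a number 50 percentage points lower from compound 1 to compound 3 (beyond the scatter) when 2-phenylethenyl is the group replaced. This carbon looked indifferent to its group while only 2-phenylethenyl and 4-methoxyphenyl were compared, but the new compound shows that the group here can decide whether any effect is seen at the tested concentration. No measurement at hand says why the 3-nitrophenyl group behaves this way.

The 3-nitrophenyl group differs from 4-methoxyphenyl both in what the ring carries and in where it carries it, and the compounds shown cannot separate these two differences. As far as these compounds go, it also stays open whether the loss belongs to the nitro group alone, or whether an amine or a carboxylic acid on that ring would give the same result.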